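This account rests on a few compounds, and the source may have more. Where it says the series, first, only, none or still open, it means among the compounds named here.

In a functional assay on SW-620 cells (Homo sapiens) for cytotoxicity, read by MTT assay, with a stated time of 72 h (on this read-out higher numbers stand for weaker inhibition and lower numbers for stronger inhibition), three compounds sharing one core have been measured. Compound 1 `COc1ccc(/C=C2\CCC/C(=C\c3cccc(Cl)c3)C2=O)cc1OC` gives 5100 nM, compound 2 `COc1ccc(/C=C2\CCC/C(=C\c3cccc(Br)c3)C2=O)cc1OC` gives 4200 nM, and compound 3 `COc1ccc(/C=C2\CCC/C(=C\c3ccc(Cl)cc3Cl)C2=O)cc1OC` gives 10300 nM, the highest number of the three. Compound 4 `COc1cc(/C=C2\CCC/C(=C\c3ccc(OC)c(OC)c3)C2=O)ccc1O` differs from it as follows: 4-hydroxy-3-methoxyphenyl in place of 2,4-dichlorophenyl on a double-bonded chain carbon bound to a double-bonded ring carbon. Two measured steps change the group at this place: a 2.0-fold higher number from compound 1 to compound 3 (0.31 log units; beyond the scatter), and a 2.5-fold higher number from compound 2 to compound 3 (0.39 log units; beyond the scatter). Both are modest, while a 1.2-fold lower number from compound 1 to compound 2 (0.08 log units; within the scatter) stays within the scatter. Going by the values given here, no measured compound carries the entering group at this place, so the direction is uncertain. A modest move towards a lower number is nevertheless expected in this assay, and the estimated step is a 1.9-fold lower number from compound 3 to compound 4 (0.27 log units; within the scatter). For compound 4 the estimated value is 5500 nM, with an expected range from 1800 nM to 15000 nM.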

Compound 4, half-maximal inhibitory concentration: 4500 nM
Estimate against measurement, compound 4: 1.2-fold (0.09 log units) above; measured number inside the range.
By their numbers in this assay, from the lowest: compounds 2, 4 and 1 (each within the scatter of the next); then compound 3.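

In this assay, placing 4-hydroxy-3-methoxyphenyl on the double-bonded chain carbon bound to a double-bonded ring carbon gives a 2.3-fold lower number from compound 3 to compound 4 (0.36 log units; beyond the scatter), so a group with a hydrogen-bond donor and acceptors is accommodated at this place. Going by these compounds alone, the other two steps, a 1.1-fold higher number from compound 2 to compound 4 (0.03 log units; within the scatter) and a 1.1-fold lower number from compound 1 to compound 4 (0.05 log units; within the scatter), lie within the scatter, leaving 2,4-dichlorophenyl as the only group here that stands apart. Nothing available explains this result.

The compounds shown leave open whether the hydroxy or the methoxy group matters more, and how an amine or a carboxylic acid would behave at this place.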